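The compounds below may be only part of what the source reports. "The series", "measured", "known", "first", "only" and "open" are said of these compounds alone.

Compound 1 `O=C(O)C12CCC(C(=O)N3CC[C@](c4ccc(C(F)(C(F)(F)F)C(F)(F)F)cc4)(S(=O)(=O)c4ccc(F)cc4)C3)(CC1)OC2`: 90%
Compound 2 `CCC1(C(=O)N2CC[C@](c3ccc(C(F)(C(F)(F)F)C(F)(F)F)cc3)(S(=O)(=O)c3ccc(F)cc3)C2)CCS(=O)(=O)CC1`: 3%

In an ADME assay on microsomes from liver (Homo sapiens) for metabolic stability, with a stated time of 10 min (on this read-out higher numbers stand for a more stable compound and lower numbers for a less stable compound), compound 2 stands lower of the two, at 3%. Compound 3 `O=C(N1CC[C@](c2ccc(C(F)(C(F)(F)F)C(F)(F)F)cc2)(S(=O)(=O)c2ccc(F)cc2)C1)C1(O)CCS(=O)(=O)CC1` has hydroxy in place of ethyl on a saturated ring carbon. Going by the values given here, the only measured step is a number 87 percentage points lower from compound 1 to compound 2 (beyond the scatter), which is large and beyond the scatter. It replaces a whole group on the carbonyl carbon, so it is only a loose guide, though it shows that this part can shift the read-out widely. Compound 2 at 3% has little room to fall. A sizeable upward move is therefore expected: a number 47 percentage points higher from compound 2 to compound 3 (beyond the scatter). Compound 3 is estimated at 50%, within an expected range of 15% to 88%.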

Compound 3, percent of the compound remaining: 100%
Compound 3: middle estimate off by 50 percentage points, on the low side, outside the stated range (above it).
By their numbers in this assay, from the lowest: compound 2; then compounds 1 and 3 (each within the scatter of the next).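

In this assay, exchanging only ethyl for hydroxy on a saturated ring carbon gives a number 97 percentage points higher from compound 2 to compound 3 (beyond the scatter), so this one change is enough for a shift of this size, with the rest of the group on the carbonyl carbon kept. The step of a number 10 percentage points higher from compound 1 to compound 3 (within the scatter) shows that two quite different groups on the carbonyl carbon can give results that cannot be told apart here. No measurement shown explains why the read-out moves. Open, on these data alone, is whether losing ethyl or gaining hydroxy drives the shift; an amine or a methoxy group on the same ring carbon would help separate the two.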